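Cyano to trifluoromethyl on the shared core

The source may hold more compounds than are shown below. What is called first, only, known or untested is meant among the compounds shown, and "the series" means these compounds.

Measured compounds:
compound 1 `CCc1nnc2c(C#N)c(N3CCC(c4ccccc4)CC3)ccn12` 247%
compound 2 `CCCc1nnc2c(C#N)c(N3CCC(c4ccccc4)CC3)ccn12` 272%
compound 3 `COCc1nnc2c(C#N)c(N3CCC(c4ccccc4)CC3)ccn12` 196%

In a functional assay on CHO cells for positive allosteric modulation of metabotropic glutamate receptor 2 (Homo sapiens), read by GTPgammaS binding, with a stated time of 30 min (on this read-out higher numbers stand for larger maximal responses and lower numbers for smaller maximal responses), compound 1 stands second highest of the three. Its nearest neighbour is compound 2, which gives a number 25 percentage points higher from compound 1 to compound 2 (beyond the scatter); its furthest is compound 3, which gives a number 51 percentage points lower from compound 1 to compound 3 (beyond the scatter), and between the other two the step is a number 76 percentage points lower from compound 2 to compound 3 (beyond the scatter). All three measured steps change only the substituent on the saturated chain carbon bound to the core; none touches the aromatic carbon that carries the cyano group.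

Compound 4 `CCc1nnc2c(C(F)(F)F)c(N3CCC(c4ccccc4)CC3)ccn12` differs from compound 1 by trifluoromethyl in place of cyano on an aromatic carbon. Among the compounds with values here, no measured step bears directly on this position, so the data give no direction for the change; the working expectation in this assay is therefore a step of no size beyond the scatter, with a wide range to reflect the missing precedent. The estimated step is a number 7 percentage points lower from compound 1 to compound 4 (within the scatter). Compound 4 is accordingly expected to give about 240%, in a range from 170% to 300%.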

Compound 4, largest response reached (Emax), in percent of the reference or control that the assay uses: 334%
The estimate for compound 4 lay 94 percentage points below the measured number; measured number above the stated range.
By their numbers in this assay, from the lowest: compound 3; then compound 1; then compound 2; then compound 4.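

In this assay, the aromatic carbon carrying the nitrile proves to be a sensitive position: a number 87 percentage points higher from compound 1 to compound 4 (beyond the scatter). This step is larger than either change on the saturated chain carbon, a number 25 percentage points higher from compound 1 to compound 2 (beyond the scatter) and a number 51 percentage points lower from compound 1 to compound 3 (beyond the scatter). The position accepts trifluoromethyl, with its greater heavy-atom count and no hydrogen-bond acceptor, without loss of maximal response, but nothing available explains the rise.

With only one replacement for the nitrile shown, it remains open whether a chlorine atom, a methyl group or a carboxamide on this carbon would follow trifluoromethyl or the nitrile. Also open, going by these compounds, is whether trifluoromethyl would give a step of similar size on the chains of compound 2 and compound 3.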